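Isopropyl replaces 4-isopropylphenyl on the ether chain of compound 3

The compounds below may be only part of what the source reports. "The series", "measured", "known", "first", "only" and "open" are said of these compounds alone.

Three compounds share a core and differ only in the group on a saturated chain carbon bound to an oxygen on an aromatic ring. In a functional assay on RAW264.7 cells (Mus musculus) for inhibition, read by immunoassay, with a stated time of 12 h, tested at 30 uM (on this read-out lower numbers stand for less inhibition and higher numbers for more inhibition at the one concentration tested (going by the name of the read-out)), compound 1 `O=C1CC(c2ccccc2OCc2ccc(F)cc2)Oc2ccccc21` gives 45.2%, compound 2 `CCCOc1ccccc1C1CC(=O)c2ccccc2O1` gives 45.7%, and compound 3 `CC(C)c1ccc(COc2ccccc2C2CC(=O)c3ccccc3O2)cc1` gives 91.5%. Compound 3 stands highest of the three, with a number 45.8 percentage points higher from compound 2 to compound 3 (beyond the scatter) and a number 46.3 percentage points higher from compound 1 to compound 3 (beyond the scatter), both beyond the scatter, while a number 0.5 percentage points higher from compound 1 to compound 2 (within the scatter) lies within it.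

Compound 4 `CC(C)COc1ccccc1C1CC(=O)c2ccccc2O1` is not yet measured. Its change from compound 3 is isopropyl in place of 4-isopropylphenyl on a saturated chain carbon bound to an oxygen on an aromatic ring. For the measured compounds named here, the step that bears on it most directly is the one from compound 2 to compound 3, where a 4-isopropylphenyl group entered in place of an ethyl at the same position and the read-out in this assay rose by a large amount. Compound 4 carries a small alkyl at that position, as compound 2 does, so a large step downward in this assay is expected, roughly reversing the earlier gain, with a number 41.5 percentage points lower from compound 3 to compound 4 (beyond the scatter).

On that basis compound 4 is estimated to give 50% in this assay, with a range from 30% to 75%.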

Compound 4, a percentage reported as inhibition, at one concentration (the size of the read-out at that concentration, not a potency): 30.4%
Compound 4: the middle estimate sits 19.6 percentage points above what was measured, and the stated range covers the measured number.
By their numbers in this assay, from the lowest: compound 4; then compounds 1 and 2 (each within the scatter of the next); then compound 3.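

In this assay, the change gives a number 61.1 percentage points lower from compound 3 to compound 4 (beyond the scatter), so the isopropyl group alone, now placed on the saturated chain carbon bound to an oxygen on an aromatic ring, does not retain the high read-out of the 4-isopropylphenyl group. The small alkyl groups are also not interchangeable at this place: the added methyl gives a number 15.3 percentage points lower from compound 2 to compound 4 (beyond the scatter), and replacing 4-fluorophenyl with isopropyl gives a number 14.8 percentage points lower from compound 1 to compound 4 (beyond the scatter), which shows that the level shared by compound 1 and compound 2 is not a floor for this series. Nothing among the data shown accounts for these differences.

The compounds shown leave open whether the high read-out of compound 3 depends on the aromatic ring itself or on the isopropyl group carried by that ring, a question that a plain phenyl or a cyclohexyl group at this place would bear on. They also leave open how a longer chain, such as hexyl, or an amine at the end of the chain would behave in this assay.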